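Aryl ether swap on the shared core, expected outcome

This account rests on a few compounds, and the source may have more. Where it says the series, first, only, none or still open, it means among the compounds named here.

Compound 1 `Cc1nn(C)c(Oc2ccc(Br)cc2)c1/C=N\CCCCCOc1cc2oc(=O)cc(C)c2cc1Cl` gives 13800 nM in a functional assay on HepG2 cells (Homo sapiens) for antiproliferative activity, read by MTT assay, with a stated time of 72 h; a higher number here means a weaker inhibitor, a lower number a stronger inhibitor. Compound 2 `Cc1nn(C)c(Oc2cccc(F)c2)c1/C=N\CCCCCCOc1cc2oc(=O)cc(C)c2cc1Cl` in this assay returns only a limit, > 25000 nM, and so sits at the limit of > 25000 nM in this assay, at which 1 of the 2 values shown sits. Compound 3 `Cc1nn(C)c(Oc2ccccc2Br)c1/C=N\CCCCCCOc1cc2oc(=O)cc(C)c2cc1Cl` differs from compound 2 by 2-bromophenyl in place of 3-fluorophenyl on an oxygen on an aromatic ring. Among the measured compounds shown here, no measured step covers this change, so the step from compound 2 to compound 3 is expected to fall within the scatter, though a modest gain could bring compound 3 to a number rather than a limit. The estimate for compound 3 in this assay is 20000 nM, with a range from 8000 nM to 40000 nM. The expected step is an at least 1.2-fold lower number from compound 2 to compound 3 (0.09 log units; that floor lies within the scatter).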

Compound 3, half-maximal inhibitory concentration: 24200 nM
The estimate for compound 3 lay 1.2-fold (0.08 log units) below the measured number, within the range that was stated.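

Moving from 3-fluorophenyl to 2-bromophenyl on this oxygen yields a number rather than only a limit in this assay, with an at least 1.0-fold lower number from compound 2 to compound 3 (0.01 log units; that floor lies within the scatter). Going by these compounds, that step is only a floor, and the true gap stays unknown, because compound 2 is held at a limit: the limit of > 25000 nM in this assay, at which 1 of the 3 values shown sits. A gain beyond the scatter is therefore neither shown nor excluded for this change.

Open, on these data alone, is whether an amine or a carboxylic acid on this aryl ring would shift the number. Also open, as far as these compounds go, is what a longer chain does on its own, with the aryl group held fixed.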